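Swapping the Hydroxylated Ring on the Nitrogen

The compounds below may be only part of what the source reports. "The series", "measured", "known", "first", "only" and "open" are said of these compounds alone.

Of the compounds shown here, three sharing one core have been measured in an ADME assay on Huh-7 cells (Homo sapiens) for cytotoxicity; on this read-out higher numbers stand for lower toxicity in this test and lower numbers for higher toxicity in this test. Compound 1 `Cc1cc(-c2nnc(NCC3OCCO3)o2)nc2c(C(C)(C)C)cc(OCC(F)(F)F)cc12` gives 20400 nM, compound 2 `Cc1cc(-c2nnc(N[C@H]3C[C@@H](O)C3)o2)nc2c(C(C)(C)C)cc(OCC(F)(F)F)cc12` gives 10800 nM, and compound 3 `Cc1cc(-c2nnc(N[C@H]3C[C@H](O)C3)o2)nc2c(C(C)(C)C)cc(OCC(F)(F)F)cc12` gives 25900 nM. Compound 3 thus sits level with compound 1 within the scatter, and it stands apart only from compound 2, by a modest margin.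

Compound 4 `Cc1cc(-c2nnc(N[C@@H]3CCC[C@H](O)C3)o2)nc2c(C(C)(C)C)cc(OCC(F)(F)F)cc12` carries 3-hydroxycyclohexyl in place of 3-hydroxycyclobutyl on a nitrogen on an aromatic ring. Two measured steps change the group at this same place, a 1.9-fold lower number from compound 1 to compound 2 (0.28 log units; within the scatter) and a 1.3-fold higher number from compound 1 to compound 3 (0.10 log units; within the scatter), and both stay within the scatter. The largest step seen, a 2.4-fold higher number from compound 2 to compound 3 (0.38 log units; beyond the scatter), comes with the fact that compounds 2 and 3 differ only in the configuration as drawn. Within the data shown here, no measured step changes the ring size itself, so this evidence bears on the new change only indirectly. Since exchanging the group on this nitrogen has so far moved the number little, no shift beyond the scatter is expected in this assay. The expected step is a 1.5-fold lower number from compound 3 to compound 4 (0.18 log units; within the scatter), with a slight lean towards a lower number resting on the compound 2 value of 10800 nM showing that this series can read lower. For compound 4 the estimated value is 17000 nM, with an expected range of 8000 nM to 36000 nM.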

Compound 4, half-maximal cytotoxic concentration in the Huh-7 assay: 20900 nM
Compound 4: the middle estimate sits 1.2-fold (0.09 log units) below what was measured, and the stated range covers the measured number.
By their numbers in the Huh-7 assay, from the lowest: compounds 2, 1, 4 and 3 (each within the scatter of the next, the first and the last beyond it).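

Among these compounds, in the Huh-7 assay compound 4 gives 20900 nM, and the first step to change the ring size itself, a 1.2-fold lower number from compound 3 to compound 4 (0.09 log units; within the scatter), shows that going from the four-membered to the six-membered ring leaves the number within the scatter, and the two other steps, a 1.9-fold higher number from compound 2 to compound 4 (0.29 log units; within the scatter) and a 1.0-fold higher number from compound 1 to compound 4 (0.01 log units; within the scatter), also stay within it. Among the compounds shown here, compound 4 therefore lies within the scatter of all three earlier compounds, and the only gap beyond the scatter remains the one between compound 2 and compound 3, which goes with this fact: the fact that compounds 2 and 3 differ only in the configuration as drawn. For the compounds shown here, in a physicochemical assay for lipophilicity, at pH 7.4 (on this read-out higher numbers stand for higher lipophilicity and lower numbers for lower lipophilicity), compound 4 gives 4, but compound 3 reads "not determined" (no result reported), so no step on this read-out can be read.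

The compounds shown leave open whether the 3-hydroxycyclohexyl group, like 3-hydroxycyclobutyl, would give numbers beyond the scatter of each other when its configuration as drawn is inverted, since only one form of it appears here. They also leave open whether an amine or a carboxylic acid in place of the hydroxyl on this ring would move the number in the Huh-7 assay beyond the scatter.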